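Compound 3: a Larger Group in Place of Cyclopropyl

The source may report more compounds than this note shows. Statements on the series, on what has been measured and on what is new or still open speak of the compounds shown alone.

Compound 2 `O=C1O[C@H]([C@@H](O)Cn2cc(C3CC3)nn2)C(OCc2ccccc2)=C1OCc1ccccc1` is one of a pair of close analogues built on the same core, and the two numbers of that pair lie within the scatter of each other. In a functional assay on HCT-116 cells (Homo sapiens) for antiproliferative activity, read by MTT assay, with a stated time of 72 h (a higher number here means a weaker inhibitor, a lower number a stronger inhibitor), compound 2 gives 30400 nM. Within the data shown here, its only neighbour is compound 1 `CCCCCCCCCCc1cn(C[C@H](O)[C@H]2OC(=O)C(OCc3ccccc3)=C2OCc2ccccc2)nn1`; in this assay compound 1 gives 28800 nM, and the step of a 1.1-fold higher number from compound 1 to compound 2 (0.02 log units; within the scatter) shows that exchanging decyl for cyclopropyl on an aromatic carbon left the read-out essentially unchanged. Compound 3 `O=C1O[C@H]([C@@H](O)Cn2cc(CNS(=O)(=O)c3ccc(Cl)cc3)nn2)C(OCc2ccccc2)=C1OCc1ccccc1` is not yet measured; it differs from compound 2 by (((4-chlorophenyl)sulfonyl)amino)methyl in place of cyclopropyl on an aromatic carbon. Among the measured compounds shown here, no measured step covers this particular group, so the only guide is the decyl-to-cyclopropyl exchange, which stayed within the scatter despite a large change in what that aromatic carbon carries. Because a 1.1-fold higher number from compound 1 to compound 2 (0.02 log units; within the scatter) was within the scatter, compound 3 is expected to land close to compound 2, with a step of about a 1.2-fold lower number from compound 2 to compound 3 (0.08 log units; within the scatter) in this assay, not beyond the scatter. Compound 3 is therefore estimated at 25000 nM, within a range from 8000 nM to 80000 nM.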

Compound 3, half-maximal inhibitory concentration: 8380 nM
The estimate for compound 3 lay 3.0-fold (0.47 log units) above the measured number; low and high end bracket the measured number.
By their numbers in this assay, from the lowest: compound 3; then compounds 1 and 2 (each within the scatter of the next).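

In this assay, this aromatic carbon proves not to be indifferent to what it carries: a 3.6-fold lower number from compound 2 to compound 3 (0.56 log units; beyond the scatter), with (((4-chlorophenyl)sulfonyl)amino)methyl in place of cyclopropyl, whereas the earlier exchange gave only a 1.1-fold higher number from compound 1 to compound 2 (0.02 log units; within the scatter). The comparison with the decyl compound agrees, with a 3.4-fold lower number from compound 1 to compound 3 (0.54 log units; beyond the scatter) for ((4-chlorophenyl)sulfonyl)amino in place of nonyl on a saturated chain carbon bound to an aromatic carbon. Among these three compounds, then, the entering group with its six-membered aromatic ring, sulfur, nitrogen and chlorine moves the number beyond the scatter, which neither a decyl chain nor a three-membered ring had done relative to each other, although both steps are modest. Nothing measured here explains this shift.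

The compounds shown leave open which part of the entering group matters, whether the chlorine, the sulfonyl or the hydrogen on its nitrogen. Going by these compounds, a phenylsulfonyl group without the chlorine, a carbonyl in place of the sulfonyl, or a methylated nitrogen would each separate these parts, and whether any of them would hold the lower number remains unknown.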